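From 2,5-dichlorophenyl to 3,4-dichlorophenyl: working notes

This account rests on a few compounds, and the source may have more. Where it says the series, first, only, none or still open, it means among the compounds named here.

Measured in a functional assay on C8166 cells (Homo sapiens) for cytotoxicity, read by MTT assay; on this read-out lower numbers stand for higher toxicity in this test and higher numbers for lower toxicity in this test:
compound 1 `Cc1cc(S(N)(=O)=O)ccc1NC(=O)COc1ccc(Cl)cc1NC(=O)c1ccccc1C`, 67300 nM
compound 2 `Cc1cc(S(N)(=O)=O)ccc1NC(=O)COc1ccc(Cl)cc1NC(=O)c1cccc(F)c1`, 243000 nM
compound 3 `Cc1cc(S(N)(=O)=O)ccc1NC(=O)COc1ccc(Cl)cc1NC(=O)c1cc(Cl)ccc1Cl`, 42100 nM

Compound 3 shares the low end of these numbers with compound 1, the gap being a 1.6-fold lower number from compound 1 to compound 3 (0.20 log units; within the scatter). Compound 2 stands apart, with a 5.8-fold lower number from compound 2 to compound 3 (0.76 log units; beyond the scatter).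

Next in line is compound 4 `Cc1cc(S(N)(=O)=O)ccc1NC(=O)COc1ccc(Cl)cc1NC(=O)c1ccc(Cl)c(Cl)c1`, which has 3,4-dichlorophenyl in place of 2,5-dichlorophenyl on a carbonyl carbon. For the measured compounds named here, no measured step exchanges one dichlorophenyl group for another, so the evidence is indirect. All three measured steps change the group at this same place. Exchanging 2-methylphenyl for 2,5-dichlorophenyl stayed within the scatter, as the step from compound 1 to compound 3 shows. Only the 3-fluorophenyl group of compound 2 departs from the other two, with a 3.6-fold higher number from compound 1 to compound 2 (0.56 log units; beyond the scatter), a modest step. A step of that modest size is therefore the largest with any precedent here. In this assay the expectation is no step beyond the scatter, with a slight lean towards a higher number. The estimate is a 1.5-fold higher number from compound 3 to compound 4 (0.19 log units; within the scatter). For compound 4 the expected value is 65000 nM, with an estimated range of 25000 nM to 170000 nM.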

Compound 4, half-maximal cytotoxic concentration: 158000 nM
Beside the measured number, compound 4's estimate is 2.4-fold (0.39 log units) below it; low and high end bracket the measured number.
By their numbers in this assay, from the lowest: compounds 3 and 1 (each within the scatter of the next); then compounds 4 and 2 (each within the scatter of the next).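

In this assay, the same atoms rearranged on the carbonyl carbon give a step beyond the scatter (a 3.8-fold higher number from compound 3 to compound 4 (0.57 log units; beyond the scatter)), so at this position the arrangement of the two chlorines matters to the read-out, and not only which atoms the group contains. The 3,4-dichlorophenyl group stays within the scatter of 3-fluorophenyl (a 1.5-fold lower number from compound 2 to compound 4 (0.19 log units; within the scatter)) but separates from 2-methylphenyl (a 2.3-fold higher number from compound 1 to compound 4 (0.37 log units; beyond the scatter)). The four compounds thus fall into two sets, with 2-methylphenyl and 2,5-dichlorophenyl at the low end and 3-fluorophenyl and 3,4-dichlorophenyl at the high end, a split that none of the four goes against but that rests on these compounds alone.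

Nothing at hand accounts for the gap between the two dichlorophenyl groups. Still open, going by these compounds, is whether the split holds for a plain phenyl, 2-chlorophenyl or 3-chlorophenyl group on the carbonyl carbon, or for a phenyl group carrying an amine or a carboxylic acid.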